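This account rests on a few compounds, and the source may have more. Where it says the series, first, only, none or still open, it means among the compounds named here.

Three related compounds have numbers in a functional assay on HCT-15 cells (Homo sapiens) for inhibition, read by MTT assay, with a stated time of 72 h; a higher number here means a weaker inhibitor, a lower number a stronger inhibitor. Compound 1 `COc1ccc(CCCNCc2c(OC)cc(Oc3ccc(Nc4ccccc4)cc3)cc2OC)cc1` gives 2180 nM, compound 3 `COc1ccc([C@@H](C)NCc2c(OC)cc(Oc3cccc(Nc4ccccc4)c3)c(OC)c2OC)cc1` gives 4690 nM, and compound 2 `COc1cc(Oc2cccc(Nc3ccccc3)c2)cc(OC)c1CN[C@H](C)c1ccccc1` gives 7550 nM. Compound 2 therefore has the highest of the three numbers, although its value lies within the usual scatter of compound 3 and beyond the scatter only against compound 1. Compound 4 `COc1cc(Oc2cccc(Nc3ccccc3)c2)cc(OC)c1CNC1CC1` has cyclopropyl in place of 1-phenylethyl on an amine nitrogen. Among the measured compounds shown here, no measured pair shows a change of this kind, so the expectation is loose. In this assay the expected step is small, a 1.2-fold higher number from compound 2 to compound 4 (0.08 log units; within the scatter), and stays within the scatter. For compound 4 the estimated value is 9000 nM, with an expected range of 3000 nM to 27000 nM.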

Compound 4, half-maximal inhibitory concentration: 6140 nM
For compound 4 the middle estimate is 1.5-fold (0.17 log units) above the measured one, and the stated range covers the measured number.
By their numbers in this assay, from the lowest: compound 1; then compounds 3, 4 and 2 (each within the scatter of the next).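

In this assay, cyclopropyl in place of 1-phenylethyl on the amine nitrogen gives a 1.2-fold lower number from compound 2 to compound 4 (0.09 log units; within the scatter) and so leaves compound 2 and compound 4 indistinguishable. At this position, the six-membered aromatic ring and the defined stereocentre can therefore leave with 1-phenylethyl without a change beyond the scatter. No evidence is available to explain this result.

From the compounds shown here alone, it remains open whether a longer chain ending in a carboxylic acid on this nitrogen would shift the number beyond the scatter. The same question stands for a simple methyl group there.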